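This account rests on a few compounds, and the source may have more. Where it says the series, first, only, none or still open, it means among the compounds named here.

Measured so far:
compound 1 `CCCCc1oc2ccc(/N=C/c3ccc(O)cc3)cc2c1C(=O)c1ccc(OC)cc1` — 22.8 ug/mL
compound 2 `CCCCc1oc2ccc(/N=C/c3cccc([N+](=O)[O-])c3)cc2c1C(=O)c1ccc(OC)cc1` — 34.2 ug/mL

In a functional assay, with a stated time of 30 min (a higher number here means a weaker inhibitor, a lower number a stronger inhibitor), compound 2 gives the higher of the two numbers shown, but the gap to compound 1 is within the scatter: a 1.5-fold higher number from compound 1 to compound 2 (0.18 log units; within the scatter). Compound 3 `CCCCc1oc2ccc(/N=C/c3ccc(Cl)cc3)cc2c1C(=O)c1ccc(OC)cc1` differs from compound 2 in one place: 4-chlorophenyl in place of 3-nitrophenyl on a carbon with a double bond to nitrogen. Among the compounds with values here, the one measured step, a 1.5-fold higher number from compound 1 to compound 2 (0.18 log units; within the scatter), also exchanged the aryl group on this carbon and stayed within the scatter, so for compound 3 no step beyond the scatter is expected in this assay: a 1.1-fold lower number from compound 2 to compound 3 (0.06 log units; within the scatter). Compound 3 is estimated at 30 ug/mL, with a range from 15 ug/mL to 60 ug/mL.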

Compound 3, half-maximal inhibitory concentration: 75.9 ug/mL
Estimate against measurement, compound 3: 2.5-fold (0.40 log units) below; the whole stated range lies below it.
By their numbers in this assay, from the lowest: compounds 1 and 2 (each within the scatter of the next); then compound 3.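

In this assay the aryl group on the carbon with a double bond to nitrogen can shift the number beyond the scatter, which the earlier pair did not show: a 2.2-fold higher number from compound 2 to compound 3 (0.35 log units; beyond the scatter) comes with 4-chlorophenyl in place of 3-nitrophenyl. Chloro in place of hydroxy on an aromatic carbon brings a 3.3-fold higher number from compound 1 to compound 3 (0.52 log units; beyond the scatter) and makes compound 3 the weakest inhibitor of the three. Nothing measured here explains this change. From the compounds shown here alone, whether an aryl group carrying an amine or a carboxylic acid on this carbon would give a lower number than compound 1 remains open.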